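The source may report more compounds than this note shows. Statements on the series, on what has been measured and on what is new or still open speak of the compounds shown alone.

Compound 2 `Cc1cc(C)cc(S(=O)(=O)c2c(C(=O)N[C@@H]3CCN(CC(N)=O)C3)[nH]c3ccc(Cl)cc23)c1` and compound 1 `Cc1cc(C)cc(S(=O)(=O)c2c(C(=O)N[C@@H]3CCN(Cc4n[nH]c(=O)n4C)C3)[nH]c3ccc(Cl)cc23)c1` share a core and differ on the ring amine; in an ADME assay on MT4 cells (Homo sapiens) for cytotoxicity, read by MTT assay, with a stated time of 5 days (a lower number here means that less compound is tolerated, a higher number that more compound is tolerated), compound 1 gives 22400 nM and compound 2 gives 31000 nM, the two numbers lying a 1.4-fold higher number from compound 1 to compound 2 (0.14 log units; within the scatter), so compound 2 stands with compound 1 within the scatter. Compound 3 `CCS(=O)(=O)NC(=O)c1[nH]c2ccc(Cl)cc2c1S(=O)(=O)c1cc(C)cc(C)c1` carries ethylsulfonyl in place of 1-(carbamoylmethyl)pyrrolidin-3-yl on an amide-type nitrogen. Among the measured compounds shown here, the single measured step changed only a group on the ring amine nitrogen and does not bear on removing that whole ring in favour of ethylsulfonyl, so no direction is indicated. Compound 3 is therefore expected near the two measured values, at 25000 nM with a range from 8000 nM to 70000 nM, a step of a 1.2-fold lower number from compound 2 to compound 3 (0.09 log units; within the scatter) that is an estimate only.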

Compound 3, half-maximal cytotoxic concentration: > 283000 nM
Compound 3 was reported as a limit; the forecaster's own chance of this, stated with the estimate: 20%; at least 11-fold (1.05 log units) between middle value and limit.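

In this assay, ethylsulfonyl in place of 1-(carbamoylmethyl)pyrrolidin-3-yl on the amide-type nitrogen gives an at least 9.1-fold higher number from compound 2 to compound 3 (0.96 log units; beyond the scatter), the first step shown that lies beyond the scatter. The earlier change, on the ring amine nitrogen, stayed within it. Compound 3 is reported only as a limit, so the full size of this step stays unknown: the limit of > 283000 nM in this assay, at which 1 of the 3 values shown sits.

From the compounds shown here alone, whether the rise follows the loss of the pyrrolidine ring or the arrival of the sulfonyl remains open. A simple acetyl or a phenylsulfonyl on the same nitrogen would bear on that question.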